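The source may report more compounds than this note shows. Statements on the series, on what has been measured and on what is new or still open speak of the compounds shown alone.

Working notes on the series. Three compounds share the core shown for compound 1 `Cc1nc2cc(OC[C@H](O)CN3CCN(Cc4noc(-c5ccc(C(F)(F)F)cc5)n4)CC3)ccc2s1` and have been run in a functional assay on mitochondria from heart for inhibition of peroxisomal acyl-coenzyme A oxidase 1 (Rattus norvegicus); on this read-out lower numbers stand for stronger inhibition and higher numbers for weaker inhibition. Compound 1 gives 380 nM, the lowest of the three numbers. Compound 3 `Cc1nc2cc(OC[C@H](O)CN3CCN(Cc4nnc(-c5ccc(C(C)(C)C)cc5)o4)CC3)ccc2s1` follows in this assay at 1100 nM, a higher number than compound 1 beyond the scatter. Compound 2 `Cc1nc2cc(OC[C@H](O)CN3CCN(Cc4nc(-c5ccc(C(F)(F)F)cc5)no4)CC3)ccc2s1`, in which the five-membered ring is arranged differently, gives 3630 nM, the highest of the three and again beyond the scatter from compound 1. Among the compounds with values here, no pair among the measured compounds differs in one place only, so no single isolated step is available from them.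

Compound 4 `Cc1nc2cc(OC[C@H](O)CN3CCN(Cc4noc(-c5cccc(F)c5)n4)CC3)ccc2s1` is not yet measured. Its difference from compound 1 is 3-fluorophenyl in place of 4-(trifluoromethyl)phenyl on an aromatic carbon. Nothing measured isolates this change, so the expectation rests on compound 1 at 380 nM as the starting point. The step from compound 1 to compound 4 is expected to go toward weaker inhibition, by about a 3.9-fold higher number from compound 1 to compound 4 (0.60 log units; beyond the scatter), beyond the usual scatter. On that basis compound 4 is estimated at 1500 nM, with a range from 500 nM to 5000 nM.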

Compound 4, half-maximal inhibitory concentration: 13400 nM
Compound 4: the middle estimate sits 8.9-fold (0.95 log units) below what was measured; measured number outside the range, above it.
By their numbers in this assay, from the lowest: compound 1; then compound 3; then compound 2; then compound 4.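

Within the data shown here, the step of a 35-fold higher number from compound 1 to compound 4 (1.55 log units; beyond the scatter) in this assay is the first single change isolated, and it falls on the aryl group carried by the aromatic carbon of the five-membered ring. It shows that this position is far from indifferent: with the rest of the structure held constant, replacing 4-(trifluoromethyl)phenyl with 3-fluorophenyl gives a large move toward weaker inhibition, so of these two groups 4-(trifluoromethyl)phenyl is clearly the better one here. No measurement at hand bears on why the number rises so sharply.

This one step changes both the substituent and its place on the phenyl ring, so the contribution of each remains unseparated. Also open, as far as these compounds go, is how an unsubstituted phenyl, a chlorophenyl, a methoxyphenyl or a pyridine ring would read at this position, and whether a step of similar size would appear with the five-membered ring arranged as in compound 2.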